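A Substituent on the Amide Nitrogen of Compound 1

This account rests on a few compounds, and the source may have more. Where it says the series, first, only, none or still open, it means among the compounds named here.

Within the data shown here, in a functional assay on HCT-116 cells (Homo sapiens) for antiproliferative activity, read by MTT assay, with a stated time of 72 h (on this read-out lower numbers stand for stronger inhibition and higher numbers for weaker inhibition), compound 1 `C=CC(=O)Nc1nc(-c2ccccc2)cs1` gives 18600 nM, the higher of the two actual numbers so far. Compound 2 `C=CC(=O)Nc1nc(-c2ccc(C(F)(F)F)cc2)cs1` gives 4000 nM. Compound 3 `C=CC(=O)Nc1nc(-c2ccccc2O)cs1` gives > 30000 nM, which is a limit of the assay and not a number.

Compound 4 `C=CC(=O)N(CC(=O)OC)c1nc(-c2ccccc2)cs1` has not yet been measured. It carries (methoxycarbonyl)methyl in place of hydrogen on an amide-type nitrogen of compound 1: (methoxycarbonyl)methyl in place of hydrogen on an amide-type nitrogen. Two measured steps offer only a rough scale, since both change an aromatic carbon and neither touches this nitrogen. The first is a 4.7-fold lower number from compound 1 to compound 2 (0.67 log units; beyond the scatter), and the second is an at least 1.6-fold higher number from compound 1 to compound 3 (0.20 log units; that floor lies within the scatter). With no measured change at the nitrogen, a step no larger than the modest one to compound 2 is expected, most likely none beyond the scatter, with a slight lean toward a higher number. The expected step is a 1.2-fold higher number from compound 1 to compound 4 (0.07 log units; within the scatter). In this assay, compound 4 is estimated at 22000 nM, with an expected range from 6000 nM to 60000 nM.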

Compound 4, half-maximal inhibitory concentration: > 30000 nM
Compound 4 ended at the assay's limit; the forecaster's own chance of this, stated with the estimate: 35%; middle value at least 1.3-fold (0.13 log units) away from the limit.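

Of the changes shown, this is the only one at the amide-type nitrogen and not on an aromatic carbon. In this assay it gives an at least 1.6-fold higher number from compound 1 to compound 4 (0.20 log units; that floor lies within the scatter) with no move toward a lower number such as the trifluoromethyl change produced. Compound 4 gives a limit and not a number, so this step has only a floor, and a change at the nitrogen now ends at the same limit as one on an aromatic carbon: the limit of > 30000 nM in this assay, at which 2 of the 4 values shown sit.

The compounds shown leave open whether methyl, a carboxylic acid or an amine-bearing chain on this nitrogen would give a number under that limit. They also leave open whether the trifluoromethyl group would keep its effect with (methoxycarbonyl)methyl on the nitrogen.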